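Replacing isoquinolin-3-yl in compound 3

The compounds below may be only part of what the source reports. "The series", "measured", "known", "first", "only" and "open" are said of these compounds alone.

Measured in a functional assay (blood) for inhibition, with Homo sapiens as the target; a higher number here means a weaker inhibitor, a lower number a stronger inhibitor:
- Compound 1 `CC(C)(C)Sc1c(CC(C)(C)C(=O)O)n(Cc2ccc(Cl)cc2)c2ccc(CCc3ccc4ccccc4n3)cc12`: > 3000 nM, a limit
- Compound 2 `CC(C)(C)Sc1c(CC(C)(C)C(=O)O)n(Cc2ccc(Cl)cc2)c2ccc(OCc3ccc4cc(F)ccc4n3)cc12`: 880 nM
- Compound 3 `CC(C)(C)Sc1c(CC(C)(C)C(=O)O)n(Cc2ccc(Cl)cc2)c2ccc(OCc3cc4ccccc4cn3)cc12`: > 3000 nM, a limit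

Compound 3 stands only at a limit, > 3000 nM, which is the limit of > 3000 nM in this assay, at which 2 of the 3 values shown sit. The move to compound 4 `CC(C)(C)Sc1c(CC(C)(C)C(=O)O)n(Cc2ccc(Cl)cc2)c2ccc(OCc3ccc4cccnc4n3)cc12` is a group of 10 heavy atoms (8 carbon, 2 nitrogen; 2 six-membered aromatic rings with 1 hetero atom each) in place of a group of 10 heavy atoms (9 carbon, 1 nitrogen; one six-membered aromatic ring of carbon only, one six-membered aromatic ring with 1 hetero atom), on a saturated chain carbon bound to an oxygen on an aromatic ring. Within the data shown here, the one readable guide is an at least 3.4-fold higher number from compound 2 to compound 3 (0.53 log units; beyond the scatter), which sets isoquinolin-3-yl against 6-fluoroquinolin-2-yl. The other measured step, a step that the two limits leave unreadable from compound 1 to compound 3, gives no size. Compound 4 carries neither of these groups, so that guide is indirect, and only a modest move toward a lower number is expected in this assay. The expected step is an at least 1.6-fold lower number from compound 3 to compound 4 (0.22 log units; that floor lies within the scatter). Compound 4 is estimated at 1800 nM, with an expected range of 600 nM to 5000 nM.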

Compound 4, half-maximal inhibitory concentration: > 3000 nM
Compound 4 gave a limit, no number; the forecaster's own chance of this, stated with the estimate: 40%; middle value at least 1.6-fold (0.22 log units) from the limit.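

Compound 4 gives only a limit, not a number, in this assay, and it joins the values held at that ceiling: the limit of > 3000 nM in this assay, at which 3 of the 4 values shown sit.

The readable step is an at least 3.4-fold higher number from compound 2 to compound 4 (0.53 log units; beyond the scatter), so a second group in place of 6-fluoroquinolin-2-yl on this saturated chain carbon also ends weaker, as isoquinolin-3-yl did. The steps to compound 4 from compound 1 and compound 3 cannot be read.

On these data alone, the order of compound 3 and compound 4 stays open. So does whether plain quinolin-2-yl, or a chloro or methoxy group in place of the fluorine, would match compound 2.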